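Adding a Methoxy Group to an Aminochalcone Core

A few compounds are considered here, and "the series" means these few. Any claim that something is new, unique, unknown or untested is made for them only; others in the source may bear on it.

Compound 1 `C=C(Br)C(=O)Nc1ccc(C(=O)/C=C/c2ccccc2)cc1` and compound 2 `C=C(Br)C(=O)Nc1ccc(C(=O)/C=C/c2ccccc2OC)cc1` share one core. In a functional assay on HeLa cells (Homo sapiens) for antiproliferative activity, with a stated time of 48 h (on this read-out higher numbers stand for weaker inhibition and lower numbers for stronger inhibition), compound 1 gives 960 nM, and compound 2 gives 1300 nM. The two differ by methoxy in place of hydrogen on an aromatic carbon, a step of a 1.4-fold higher number from compound 1 to compound 2 (0.13 log units; within the scatter). Compound 3 `COc1ccc(/C=C/C(=O)c2ccc(N)cc2)c(OC)c1` rests on a different core; how its core differs from that of compound 1 is not broken down here. In this assay compound 3 gives 22000 nM. Compound 4 `COc1ccc(/C=C/C(=O)c2ccc(N)cc2)c(OC)c1OC` differs from compound 3 by methoxy in place of hydrogen on an aromatic carbon. This is the same kind of change as that from compound 1 to compound 2, yet the surroundings differ: in compound 2 the new group sits ortho to a large group, whereas in compound 4 it sits ortho to two methoxy groups and meta to a large group. Because the step of a 1.4-fold higher number from compound 1 to compound 2 (0.13 log units; within the scatter) was small, compound 4 is expected to show a step of no change at the digits printed from compound 3 to compound 4 (within the scatter). Compound 4 is estimated at 22000 nM, between 8000 nM and 60000 nM.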

Compound 4, half-maximal inhibitory concentration: 8200 nM
The estimate for compound 4 lay 2.7-fold (0.43 log units) above the measured number; the range from low to high includes it.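

In this assay, methoxy in place of hydrogen on an aromatic carbon brings a 2.7-fold lower number from compound 3 to compound 4 (0.43 log units; beyond the scatter), so on this core the change lowers the number, whereas on the core of compound 1 it left the number within the scatter. The two steps do not match: the same change on two cores in this assay, a 1.4-fold higher number (0.13 log units; within the scatter) from compound 1 to compound 2 and a 2.7-fold lower number (0.43 log units; beyond the scatter) from compound 3 to compound 4, 3.6-fold (0.56 log units) apart, beyond the scatter of two such steps. This shows that the size of the step did not carry over from one core to the other, but it does not show why: the cores differ and the new group stands in different surroundings, and two pairs set no rule for the series.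

The compounds shown leave open whether a hydroxy group or a chlorine atom at the same place would shift the number as methoxy does. They also leave open how methoxy would act on the core of compound 1 in surroundings like those in compound 4.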